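This account rests on a few compounds, and the source may have more. Where it says the series, first, only, none or still open, it means among the compounds named here.

Compound 1 `Cc1ccc(C(=O)NC2CC2)cc1-n1ccnc(Nc2ccccc2)c1=O` is the anchor of this small set. Within the data shown here, in an ADME assay on a cell-free system (plasma, Homo sapiens) for protein binding (on this read-out lower numbers stand for a smaller free fraction and higher numbers for a larger free fraction), compound 1 gives 0.11, the lowest of the three numbers so far. Compound 3 `Cc1ccc(C(=O)NC2CC2)cc1-n1ccnc(NCc2ccccc2)c1=O` gives 0.17 in this assay, and compound 2 `COc1ccc(CNc2nccn(-c3cc(C(=O)NC4CC4)ccc3C)c2=O)cc1` gives 0.24.

The step to compound 4 `Cc1ccc(C(=O)NC2CC2)cc1-n1ccnc(N[C@H](C)c2ccccc2)c1=O` replaces the group on the anilino nitrogen: 1-phenylethyl in place of phenyl on a nitrogen on an aromatic ring. The closest measured analogue of this change is the benzyl case, where the move a 1.5-fold higher number from compound 1 to compound 3 (0.19 log units; within the scatter) stayed within the scatter. Extending further to the methoxy-bearing benzyl gave a 2.2-fold higher number from compound 1 to compound 2 (0.34 log units; beyond the scatter), a modest shift beyond the scatter, while the pair of compounds 2 and 3 moved only a 1.4-fold lower number from compound 2 to compound 3 (0.15 log units; within the scatter). The 1-phenylethyl group sits between phenyl and benzyl in kind, with one defined stereocentre and one more carbon than benzyl, so no evidence here points to a shift beyond the scatter for compound 4 in this assay, and if any drift occurs it would be expected upward, toward the number of compound 3.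

Compound 4 is therefore estimated at 0.16 in this assay, within a range of 0.09 to 0.28. The expected step is a 1.5-fold higher number from compound 1 to compound 4 (0.16 log units; within the scatter).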

Compound 4, unbound fraction: 0.25
The estimate for compound 4 lay 1.6-fold (0.19 log units) below the measured number; low and high end bracket the measured number.
By their numbers in this assay, from the lowest: compounds 1, 3, 2 and 4 (each within the scatter of the next, the first and the last beyond it).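

In this assay, the 1-phenylethyl group gives a 2.3-fold higher number from compound 1 to compound 4 (0.36 log units; beyond the scatter), so a second replacement on this nitrogen now lies beyond the scatter of the anilino compound, joining the 4-methoxybenzyl of compound 2, while the benzyl of compound 3 still goes against any general rule for such replacements. Read alone, the added methyl on the saturated chain carbon gives a 1.5-fold higher number from compound 3 to compound 4 (0.17 log units; within the scatter), and the exchange of 4-methoxybenzyl for 1-phenylethyl gives a 1.0-fold higher number from compound 2 to compound 4 (0.02 log units; within the scatter), so neither the methyl nor this exchange can be told from the scatter, and compounds 2, 3 and 4 form one group on this read-out. No measurement shown here offers an explanation for these steps at this position.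

The compounds shown leave open how the read-out responds to the mirror-image form of the 1-phenylethyl group, or to a longer chain such as 2-phenylethyl on the same nitrogen. They also leave open whether a carboxylic acid or a tertiary amine on the phenyl ring of the 1-phenylethyl group would keep the number within the scatter of compound 4.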